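Chain length and cytotoxicity in a hydrazone series

The compounds below may be only part of what the source reports. "The series", "measured", "known", "first", "only" and "open" are said of these compounds alone.

Two compounds share a core and differ only in a side chain. Compound 1 `CN(C)CCNc1nc(N/N=C/c2ccc(F)cc2)nc2ccccc12` gives 1820 nM in a functional assay on HepG2 cells (Homo sapiens) for cytotoxicity, read by MTT assay, with a stated time of 72 h; on this read-out higher numbers stand for weaker inhibition and lower numbers for stronger inhibition. Compound 2 `CN(C)CCCNc1nc(N/N=C/c2ccc(F)cc2)nc2ccccc12` gives 880 nM. The change between them is (dimethylamino)methyl in place of dimethylamino on a saturated chain carbon, two bonds along the chain from a nitrogen on an aromatic ring, and it made a step of a 2.1-fold lower number from compound 1 to compound 2 (0.32 log units; beyond the scatter).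

Compound 3 `CN(C)CCNc1nc(N/N=C/c2nccn2Cc2ccccc2)nc2ccccc12` carries a different core, and the difference between the two cores is not broken down here. In this assay compound 3 gives 9600 nM, the highest number among the three measured compounds.

Compound 4 `CN(C)CCCNc1nc(N/N=C/c2nccn2Cc2ccccc2)nc2ccccc12` is not yet measured. For the measured compounds named here, it differs from compound 3 by (dimethylamino)methyl in place of dimethylamino on a saturated chain carbon, two bonds along the chain from a nitrogen on an aromatic ring, the same change as the one from compound 1 to compound 2, at the same place. Going by the values given here, because the only precedent for this change is a 2.1-fold lower number from compound 1 to compound 2 (0.32 log units; beyond the scatter), a step of similar size is expected here, and for compound 4 the expected step is a 2.1-fold lower number from compound 3 to compound 4 (0.32 log units; beyond the scatter). On that basis compound 4 is estimated at 4600 nM, with a likely range from 2200 nM to 9600 nM.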

Compound 4, half-maximal inhibitory concentration: 4040 nM
Compound 4: middle estimate off by 1.1-fold (0.06 log units), on the high side, and the stated range covers the measured number.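

Changing the side chain from (2-(dimethylamino)ethyl)amino to (3-(dimethylamino)propyl)amino on the core of compound 3 gives, in this assay, a 2.4-fold lower number from compound 3 to compound 4 (0.38 log units; beyond the scatter). Set beside the earlier pair, the change carries over from one core to the other at much the same size: the same change on two cores in this assay, a 2.1-fold lower number (0.32 log units; beyond the scatter) from compound 1 to compound 2 and a 2.4-fold lower number (0.38 log units; beyond the scatter) from compound 3 to compound 4, 1.1-fold (0.06 log units) apart, within the scatter of two such steps. This shows that the step held on these two cores in this one assay, but two pairs make no general rule for other cores, and they do not explain why the longer chain gives the lower number.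

The compounds shown leave open whether a chain longer than 3-(dimethylamino)propyl would lower the number further or reverse the step, and whether a different amine at the chain end, such as diethylamino, would give a step of similar size. They also leave open whether the same step would appear on a third core or on cells other than those tested here.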